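The source may hold more compounds than are shown below. What is called first, only, known or untested is meant among the compounds shown, and "the series" means these compounds.

Working notes on the series. Compound 1 `CN1C(=O)[C@@H](NC(=O)c2n[nH]c(Cc3ccccc3)n2)COc2ncccc21` is measured in a functional assay on HT-29 cells (Homo sapiens) for inhibition, read by luminescence and CellTiter-Glo, with a stated time of 10 h; a higher number here means that more compound is needed for the effect, a lower number that less compound is needed. In this assay compound 1 reaches only a limit, > 10000 nM. Compound 2 `Cc1ccc2c(n1)OC[C@H](NC(=O)c1n[nH]c(Cc3ccccc3)n1)C(=O)N2C` carries methyl in place of hydrogen on an aromatic carbon on the shared core; in this assay compound 2 gives 363 nM. On these data alone, the step of an at least 27-fold lower number from compound 1 to compound 2 (1.44 log units; beyond the scatter) rests on one side on (the limit of > 10000 nM in this assay, at which 2 of the 3 values shown sit), so its true size stays open. Compound 3 `CN1C(=S)[C@@H](NC(=O)c2n[nH]c(Cc3ccccc3)n2)COc2ncccc21` has a core that differs from that of compound 1; the difference between the two cores is not broken down here. In this assay compound 3 again reports only a limit, > 10000 nM. Compound 4 `Cc1ccc2c(n1)OC[C@H](NC(=O)c1n[nH]c(Cc3ccccc3)n1)C(=S)N2C` is not yet measured; it stands to compound 3 as compound 2 stands to compound 1, with methyl in place of hydrogen on an aromatic carbon, the same change at the same place. For compound 4 in this assay an improvement of the order of an at least 4.0-fold lower number from compound 3 to compound 4 (0.60 log units; beyond the scatter) is expected, by analogy with the measured at least 27-fold lower number from compound 1 to compound 2 (1.44 log units; beyond the scatter). Since compound 3 gives only a limit, the size of that step is uncertain. Compound 4 is estimated at 2500 nM, within 400 nM to 10000 nM, with a real chance that only a limit is returned.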

Compound 4, half-maximal effective concentration: 122 nM
The estimate for compound 4 lay 20-fold (1.31 log units) above the measured number; the whole stated range lies above it.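

In this assay the methyl in place of hydrogen on an aromatic carbon again goes with a large step, an at least 81-fold lower number from compound 3 to compound 4 (1.91 log units; beyond the scatter), so the change points the same way on both cores: the same change on two cores in this assay, an at least 27-fold lower number (1.44 log units; beyond the scatter) from compound 1 to compound 2 and an at least 81-fold lower number (1.91 log units; beyond the scatter) from compound 3 to compound 4; the limit leaves it open whether they differ

Both steps start from a compound that reaches only a limit of the assay, and so each gives only a lower bound on the true size: the limit of > 10000 nM in this assay, at which 2 of the 4 values shown sit.

The pairs therefore show a shared direction on these two cores, and they show neither the true size of the step on either core nor whether the core alters that size.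

The compounds shown leave open what an ethyl, a chlorine atom or an amine in place of the methyl would give at the same aromatic carbon. They also leave open whether the change would carry over to a core beyond these two, or with a group other than benzyl on the shared triazole side.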